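Extending a Side Chain on a Shared Core

The source may report more compounds than this note shows. Statements on the series, on what has been measured and on what is new or still open speak of the compounds shown alone.

compound 1, `CN(O)C(=O)c1cc2ccn(Cc3ccc(F)cc3)c2cn1`: 135000 nM in an ADME assay on CEM-SS cells (Homo sapiens) for cytotoxicity, read by XTT assay; a lower number here means that less compound is tolerated, a higher number that more compound is tolerated
compound 2, `COCc1cn(Cc2ccc(F)cc2)c2cnc(C(=O)N(C)O)cc12`: 266000 nM in this assay

Within the data shown here, compound 1 holds the lower of the two numbers in this assay, and the only other number lies within the scatter: a 2.0-fold higher number from compound 1 to compound 2 (0.29 log units; within the scatter). Compound 3, `CCOCCOCc1cn(Cc2ccc(F)cc2)c2cnc(C(=O)N(C)O)cc12`, differs from compound 1 by (2-ethoxyethoxy)methyl in place of hydrogen on an aromatic carbon. Among the measured compounds shown here, the one measured step that bears on this change is the one in which methoxymethyl replaced hydrogen on an aromatic carbon, and it stayed within the scatter. A step of no greater size is therefore expected for compound 3 in this assay, as a 1.5-fold higher number from compound 1 to compound 3 (0.17 log units; within the scatter). Compound 3 is estimated at 200000 nM, with a range from 100000 nM to 400000 nM.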

Compound 3, half-maximal cytotoxic concentration: 81000 nM
Compound 3: middle estimate off by 2.5-fold (0.39 log units), on the high side, and the stated range ends above it.
By their numbers in this assay, from the lowest: compounds 3, 1 and 2 (each within the scatter of the next, the first and the last beyond it).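

In this assay, among these compounds, the longer (2-ethoxyethoxy)methyl chain gives a 3.3-fold lower number from compound 2 to compound 3 (0.52 log units; beyond the scatter) and so provides the first step at this aromatic carbon that lies beyond the scatter, though a modest one. Measured from hydrogen, the same chain gives a 1.7-fold lower number from compound 1 to compound 3 (0.22 log units; within the scatter) and so remains within the scatter of compound 1. No measurement offered here accounts for the step between the two chains. The compounds shown leave open how an intermediate chain such as ethoxymethyl would read, and whether an amine or a carboxylic acid at the end of the chain would read differently.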